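Shortening the hydroxyalkyl chain on an aminodienone

The source may hold more compounds than are shown below. What is called first, only, known or untested is meant among the compounds shown, and "the series" means these compounds.

Measured so far:
compound 1, `COCCCN1C(/C=C/c2ccc(O)cc2)=CC(=O)CC1c1ccc(O)cc1`: 91.7%
compound 2, `O=C(/C=C(/C=C/c1ccc(O)cc1)NCCCO)/C=C/c1ccc(O)cc1`: 80.5%

Both compounds were tested in an ADME assay on CHO-K1 cells (Cricetulus griseus) for activation, read by fluorescence, tested at 10 uM; on this read-out higher numbers stand for a weaker effect at the one concentration tested and lower numbers for a stronger effect. Of the two numbers, compound 2 has the lower one, and the number for compound 1 lies higher by a gap that is beyond the usual scatter, so compound 2 shows the stronger effect of the two. Among the compounds with values here, only what these two values show can be said of that pair; no step between them has been worked out.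

Compound 3, `O=C(/C=C(/C=C/c1ccc(O)cc1)NCCO)/C=C/c1ccc(O)cc1`, has not yet been measured in this assay. It differs from compound 2 in a single place: hydroxy in place of hydroxymethyl on a saturated chain carbon, two bonds along the chain from an amine nitrogen. Such a small change on the chain gives no reason, from the numbers at hand, to expect a shift beyond the scatter; the step of a number 0.5 percentage points lower from compound 2 to compound 3 (within the scatter) is therefore expected to be small, in no firm direction. Compound 3 is estimated to give 80% in this assay, within a range from 68% to 92%.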

Compound 3, a percentage reported as activity, at one concentration (the size of the read-out at that concentration, not a potency): 85.7%
Beside the measured number, compound 3's estimate is 5.7 percentage points below it; the range from low to high includes it.
By their numbers in this assay, from the lowest: compounds 2, 3 and 1 (each within the scatter of the next, the first and the last beyond it).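

In this assay, within the data shown here, taking one carbon out of the chain, 3-hydroxypropyl to 2-hydroxyethyl, gives a number 5.2 percentage points higher from compound 2 to compound 3 (within the scatter), and this is the first step here between two compounds that differ in one place. On this read-out, therefore, the two chain lengths cannot be told apart, so this change at this position leaves the number within what repeated measurements would give. No measurement available here offers an explanation for this result.

What the compounds shown leave open is whether a longer chain, such as 4-hydroxybutyl, would also read the same. On these data alone, it also remains open whether the hydroxy itself matters, which a plain ethyl chain, or an amine or a carboxylic acid in place of the hydroxy, could help to show.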